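The source may report more compounds than this note shows. Statements on the series, on what has been measured and on what is new or still open speak of the compounds shown alone.

Of the compounds shown here, three that share one core have been tested in an assay on isolated protein (Mus musculus) for inhibition of IL15-IL15 receptor (Homo sapiens), read by resazurin assay, with stated times of 30 min and 2.5 days; a higher number here means a weaker inhibitor, a lower number a stronger inhibitor. Compound 1 `Cn1c(Cc2nn(C)c(=O)c3ccccc23)nnc1SCCCCCCCCCCC(=O)Nc1ccccc1Cl` carries a long chain that ends in an amide to a chlorinated phenyl ring, and in this assay compound 1 gives 15000 nM. Compound 2 `Cn1c(Cc2nn(C)c(=O)c3ccccc23)nnc1SCC(=O)Nc1ccc(I)cc1` has a much shorter chain to an iodinated phenyl ring, and in this assay compound 2 is reported as "not active" (no number reported), so no number is available for it. Compound 3 `CC(C)COc1ccc(NC(=O)CCCCCCCSc2nnc(Cc3nn(C)c(=O)c4ccccc34)n2C)cc1` has a chain of intermediate length ending in an amide to a 4-(isobutoxy)phenyl group, and in this assay compound 3 gives 4800 nM. Of the two numbers in hand, compound 3 has the lower one, and its gap to compound 1 lies beyond the usual scatter.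

Compound 4 `Cn1c(Cc2nn(C)c(=O)c3ccccc23)nnc1SCCCCCCCC(=O)Nc1ccc(O)cc1O` keeps the core, the chain and the amide of compound 3 and differs in only one place: 2,4-dihydroxyphenyl in place of 4-(isobutoxy)phenyl on an amide-type nitrogen. Going by the values given here, no measured pair shows the effect of such a swap, so the expectation rests on thin ground. A shift to a weaker inhibitor, of moderate size, is expected, with the step from compound 3 to compound 4 estimated at a 2.5-fold higher number from compound 3 to compound 4 (0.40 log units; beyond the scatter). Compound 4 is therefore expected to give about 12000 nM in this assay, in a range from 3000 nM to 50000 nM.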

Compound 4, half-maximal inhibitory concentration: 17000 nM
Compound 4: middle estimate off by 1.4-fold (0.15 log units), on the low side; the range from low to high includes it.
By their numbers in this assay, from the lowest: compound 3; then compounds 1 and 4 (each within the scatter of the next).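

In this assay, going by these compounds alone, the step of a 3.5-fold higher number from compound 3 to compound 4 (0.55 log units; beyond the scatter) is the first comparison here in which only one group changes, with 2,4-dihydroxyphenyl in place of 4-(isobutoxy)phenyl on the amide-type nitrogen. It shows that, with the shared core and the chain held fixed, the group on this nitrogen can by itself move the number beyond the usual scatter, and that this particular swap leads to a weaker inhibitor. The swap changes several things at once, going from 11 heavy atoms to 8 and from 0 hydrogen-bond donors to 2, and nothing available bears on which of these changes matters or why the number rises.

Within the data shown here, the single step cannot separate the loss of the isobutoxy group from the arrival of the two hydroxy groups, and a plain phenyl ring, or a phenyl ring carrying one hydroxy, one methoxy or a carboxylic acid, would be needed to pull those apart. On these data alone, the effect of chain length also stays open, since compounds 1, 2 and 3 differ from one another in more than one place.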